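Primary Amide in Place of a Dimethylamide

The source may report more compounds than this note shows. Statements on the series, on what has been measured and on what is new or still open speak of the compounds shown alone.

Of the compounds shown here, three built on a shared core have been tested in an assay for positive allosteric modulation of metabotropic glutamate receptor 2 (Rattus norvegicus); a lower number here means that less compound is needed, a higher number that more compound is needed for the effect. Compound 1 `Cc1c(OCCCCOc2ccc(Cl)c(C(=O)O)c2)ccc(C(=O)CC(C)(C)C)c1O` gives 87 nM. Going by the values given here, compound 2 `Cc1ccc(OCCCCOc2ccc(C(=O)CC(C)(C)C)c(O)c2C)cc1C(=O)O` gives 210 nM; the single structural change here, a 2.4-fold higher number from compound 1 to compound 2 (0.38 log units; beyond the scatter), counts as modest. Compound 3 `Cc1c(OCCCCOc2ccc(F)c(C(=O)N(C)C)c2)ccc(C(=O)CC(C)(C)C)c1O` gives 3810 nM, the highest number of the three, well apart from compound 2 and further still from compound 1.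

Compound 4 `Cc1c(OCCCCOc2ccc(F)c(C(N)=O)c2)ccc(C(=O)CC(C)(C)C)c1O` differs from compound 3 in one place: amino in place of dimethylamino on a carbonyl carbon. Among the compounds with values here, no measured step covers a change of this kind; the only measured step, a 2.4-fold higher number from compound 1 to compound 2 (0.38 log units; beyond the scatter), concerns a substituent on an aromatic ring, not an amide. What the numbers do show is that compound 1 and compound 2, which carry a carboxylic acid where compound 3 carries a dimethylcarbamoyl group, give much lower numbers. A carbamoyl group, with its hydrogen-bond donor, may sit between those cases.

Compound 4 is therefore expected to come in near 1800 nM, somewhere between 600 nM and 5500 nM. The expected step is a 2.1-fold lower number from compound 3 to compound 4 (0.33 log units; beyond the scatter), an estimate rather than a measurement.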

Compound 4, half-maximal effective concentration: > 10000 nM
Compound 4: a limit, no number; the forecaster's own chance of this, stated with the estimate: 5%; middle value at least 5.5-fold (0.74 log units) from the limit.
By their numbers in this assay, from the lowest: compound 1; then compound 2; then compound 3. At a limit, above all of these: compound 4.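

Compound 4 gives > 10000 nM in this assay, which is a limit of the assay and not a number. Amino in place of dimethylamino on the carbonyl carbon therefore brings no gain at this position, even with the one hydrogen-bond donor it adds, and the change gives an at least 2.6-fold higher number from compound 3 to compound 4 (0.41 log units; beyond the scatter). Compared with the carboxylic acids, the 3-carbamoyl-4-fluorophenyl group gives an at least 47-fold higher number from compound 2 to compound 4 (1.67 log units; beyond the scatter) and an at least 110-fold higher number from compound 1 to compound 4 (2.06 log units; beyond the scatter), but each of these swaps also changes a second ring substituent, so the share of the acid alone cannot be read.

On these data alone, how far past the limit compound 4 lies remains open. Also open, as far as these compounds go, is what a methylamino group on the same carbonyl carbon would give, and whether a carboxylic acid paired with fluoro would keep the low numbers of compound 1 and compound 2.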